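Ring size of the thioamide amine and growth inhibition

The source may report more compounds than this note shows. Statements on the series, on what has been measured and on what is new or still open speak of the compounds shown alone.

Measured compounds:
compound 1 `N/C(=N\NC(=S)N1CCOCC1)c1ccccn1`, 14.7%
compound 2 `N/C(=N\NC(=S)N1CCCC1)c1ccc(F)cn1`, 51%
compound 3 `N/C(=N\NC(=S)N1CCCCC1)c1ccccn1`, 15.4%

In a functional assay on MCF7 cells (Homo sapiens) for cytotoxicity, read by MTT assay, with a stated time of 72 h, tested at 1 uM (a higher number here means more inhibition of growth at the concentration tested, a lower number less inhibition of growth), compound 3 gives 15.4%, the second highest of the three numbers. Its nearest neighbour is compound 1 with 14.7%, the two lying within the scatter of each other; compound 2 with 51% stands well apart, beyond the scatter. Compound 4 `N/C(=N\NC(=S)N1CCCC1)c1ccccn1` differs from compound 3 in one place: pyrrolidin-1-yl in place of piperidin-1-yl on a thiocarbonyl carbon.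

Going by the values given here, only one measured step bears on this change, and only loosely: from compound 1 to compound 3, exchanging one six-membered ring for another on the thiocarbonyl carbon, the number moved by a number 0.7 percentage points higher from compound 1 to compound 3 (within the scatter), within the scatter. Compound 2 carries the same pyrrolidin-1-yl group as compound 4 but also a fluorine on its core, so its value cannot be read as a step for the ring alone. On this thin basis the amine swap is expected to shift this assay little, though the value of compound 2 leaves room for a rise. Compound 4 is therefore estimated at 25%, with a range from 8% to 50%, an expected step of a number 9.6 percentage points higher from compound 3 to compound 4 (within the scatter).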

Compound 4, percent growth inhibition at one concentration: 45.9%
Compound 4: the middle estimate sits 20.9 percentage points below what was measured; the range from low to high includes it.
By their numbers in this assay, from the lowest: compounds 1 and 3 (each within the scatter of the next); then compounds 4 and 2 (each within the scatter of the next).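

In this assay, the amine ring on the thiocarbonyl carbon proves to matter: pyrrolidin-1-yl in place of piperidin-1-yl gives a number 30.5 percentage points higher from compound 3 to compound 4 (beyond the scatter), and pyrrolidin-1-yl in place of morpholin-4-yl gives a number 31.2 percentage points higher from compound 1 to compound 4 (beyond the scatter), whereas the exchange between the two six-membered rings had moved nothing beyond the scatter. The fluoro group on compound 2 can now be read apart from the ring, since hydrogen in place of fluoro on an aromatic carbon gives a number 5.1 percentage points lower from compound 2 to compound 4 (within the scatter), and among these compounds the two higher numbers both go with pyrrolidin-1-yl, with or without the fluoro group. Nothing on hand offers an explanation for why the five-membered ring stands apart from the two six-membered rings.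

The compounds shown leave open whether azetidin-1-yl or an open-chain amine such as dimethylamino on the thiocarbonyl carbon would keep the number of compound 4 or fall back towards that of compound 3. They also leave open how chloro or methoxy on the aromatic carbon that carries fluoro in compound 2 would read alongside pyrrolidin-1-yl.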